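Methoxy for hydrogen: one change made on two cores

The source may hold more compounds than are shown below. What is called first, only, known or untested is meant among the compounds shown, and "the series" means these compounds.

Compound 1 `CC(/C=C/CC(C)CCCC(C)C)=C\C(=O)OC(C)(C)C` and compound 2 `COC(C)(C)CCCC(C)C/C=C/C(C)=C/C(=O)OC(C)(C)C` share one core; compound 3 `CCOC(=O)/C=C(C)/C=C/CC(C)CCC(OC)C(C)C` and compound 4 `CCOC(=O)/C=C(C)/C=C/CC(C)CCC(OC)C(C)(C)OC` share another. The difference between the two cores is not broken down here. In a physicochemical assay for lipophilicity (on this read-out lower numbers stand for lower lipophilicity and higher numbers for higher lipophilicity), compound 1 gives 7.56, compound 2 gives 6.36, and compound 3 gives 5.54, the lowest of the three measured numbers. Compound 4 awaits measurement in this assay.

From compound 1 to compound 2 the change is methoxy in place of hydrogen on a saturated chain carbon bound to three saturated chain carbons. It brought a number 1.20 log units lower from compound 1 to compound 2 (beyond the scatter). From compound 3 to compound 4 the change is methoxy in place of hydrogen on a saturated chain carbon bound to three saturated chain carbons. The two changes read the same and their place is the same word for word, so this is the same change, made twice among the compounds shown.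

Among the measured compounds shown here, with only one measured instance, nothing tells whether the step carries over unchanged from the core of compound 1 to the core of compound 3. Compound 3 already stands well below both compound 1 and compound 2 in this assay. For the measured compounds named here, the expectation for compound 4 is a step of about the same size and direction as seen before, because the single measured step of a number 1.20 log units lower from compound 1 to compound 2 (beyond the scatter) is the only guide for this change. For compound 4 the estimated step is a number 1.14 log units lower from compound 3 to compound 4 (beyond the scatter). Compound 4 is therefore expected to give 4.4 in this assay, within a range from 3.9 to 4.9.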

Compound 4, partition coefficient: 4.34
Estimate against measurement, compound 4: 0.06 log units above, within the range that was stated.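

In this assay, methoxy in place of hydrogen on a saturated chain carbon bound to three saturated chain carbons gives a number 1.20 log units lower from compound 3 to compound 4 (beyond the scatter), which matches in size and direction the earlier step, a number 1.20 log units lower from compound 1 to compound 2 (beyond the scatter), so on these two cores the change carried over unchanged. This rests on two pairs on two cores, neither of which goes against the match, and it shows nothing about a further core or about the same group placed elsewhere on the chain. No measurement shown bears on why the step has this size on both cores, so the agreement stands as an observation without an explanation.

The compounds shown leave open whether another group in the same place, such as an amine, a carboxylic acid or an ethoxy group, would give a step of similar size or direction in this assay. Also open is whether the methoxy step would hold on a core carrying a carboxylic acid in place of the ester, since both cores shown are esters.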